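Ester chain shortening in the benzylidene pyridinylmethylamine series

The source may hold more compounds than are shown below. What is called first, only, known or untested is meant among the compounds shown, and "the series" means these compounds.

Within the data shown here, compound 2 `CCCCCCCCCCCCCC(=O)Oc1ccc(/C=N/Cc2cccnc2)cc1` stands at the high end of the two numbers so far: in a functional assay on MDA-MB-231 cells (Homo sapiens) for cytotoxicity (a lower number here means a stronger inhibitor, a higher number a weaker inhibitor), compound 2 gives 26600 nM, while compound 1 `CCCCCCCCCCCCCCCCCC(=O)Oc1ccc(/C=N/Cc2cccnc2)cc1` gives 11500 nM. Among the measured compounds shown here, the single measured step, a 2.3-fold higher number from compound 1 to compound 2 (0.36 log units; beyond the scatter), came with hydrogen in place of butyl on a saturated chain carbon, ten or more bonds along the chain from a carbonyl carbon, so a shorter ester chain went with a higher number.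

Compound 3 `CCCCCCC(=O)Oc1ccc(/C=N/Cc2cccnc2)cc1` has not been measured. It differs from compound 2 by hydrogen in place of heptyl on a saturated chain carbon, six bonds along the chain from a carbonyl carbon. For the measured compounds named here, only that one step bears on this change, and it was modest; the present cut is deeper and sits closer to the carbonyl, so the direction is taken from the measured step and the size is assumed somewhat larger, with wide uncertainty since no compound with a chain this short has a number. For compound 3 the expected step is a 2.3-fold higher number from compound 2 to compound 3 (0.35 log units; beyond the scatter), toward a weaker inhibitor. Compound 3 is therefore estimated at 60000 nM in this assay, within 25000 nM to 150000 nM.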

Compound 3, half-maximal inhibitory concentration: 15000 nM
Estimate against measurement, compound 3: 4.0-fold (0.60 log units) above, and the stated range ends above it.
By their numbers in this assay, from the lowest: compounds 1, 3 and 2 (each within the scatter of the next, the first and the last beyond it).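

In this assay the hydrogen in place of heptyl, six bonds along the chain from a carbonyl carbon, gives a 1.8-fold lower number from compound 2 to compound 3 (0.25 log units; within the scatter) and so does not extend the direction of the earlier step; set against the longest ester, the same compound gives a 1.3-fold higher number from compound 1 to compound 3 (0.12 log units; within the scatter) and so is not separated from either neighbour. A steady link between chain length and the number therefore does not hold across these three esters: compound 3 goes against it, and only the gap between compound 1 and compound 2 lies beyond the scatter, so a much shorter saturated chain is compatible with a number that cannot be told apart from those of both longer esters. Nothing measured on these compounds accounts for this flat reading.

The compounds shown leave open whether a still shorter acyl group, such as acetyl, would move the number beyond the scatter, and how chains of intermediate length would read. They also leave open what a terminal amine or carboxylic acid on the chain would do, as all three chains are plain saturated ones.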